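From Dimethylaminopropylsulfanyl to Pentyl on the Shared Core

This account rests on a few compounds, and the source may have more. Where it says the series, first, only, none or still open, it means among the compounds named here.

Three compounds share one core and differ only in the group on an aromatic carbon of the six-membered aromatic ring with one nitrogen. Compound 1 `CC(C)CCOc1nc(C(C)(C)C)ccc1CNC(=O)C(C)c1ccc(NS(C)(=O)=O)c(F)c1` carries isopentyloxy there, and in an assay on cells for antagonist activity at transient receptor potential cation channel subfamily V member 1 (Homo sapiens), read by FLIPR and calcium flux, with a stated time of 6 min (on this read-out higher numbers stand for weaker inhibition and lower numbers for stronger inhibition), compound 1 gives 0.8 nM. Compound 2 `CCCCCCSc1nc(C(C)(C)C)ccc1CNC(=O)C(C)c1ccc(NS(C)(=O)=O)c(F)c1` carries hexylsulfanyl, and in this assay compound 2 gives 1.5 nM; the step of a 1.9-fold higher number from compound 1 to compound 2 (0.27 log units; within the scatter) shows the two as indistinguishable. Compound 3 `CC(C(=O)NCc1ccc(C(C)(C)C)nc1SCCCN(C)C)c1ccc(NS(C)(=O)=O)c(F)c1` carries (3-(dimethylamino)propyl)sulfanyl, and in this assay compound 3 gives 51.8 nM, the highest of the three numbers; the steps of a 65-fold higher number from compound 1 to compound 3 (1.81 log units; beyond the scatter) and a 35-fold higher number from compound 2 to compound 3 (1.54 log units; beyond the scatter) set it well apart from the other two.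

Compound 4 `CCCCCc1nc(C(C)(C)C)ccc1CNC(=O)C(C)c1ccc(NS(C)(=O)=O)c(F)c1` has not yet been measured. The change from compound 3 is pentyl in place of (3-(dimethylamino)propyl)sulfanyl on an aromatic carbon. The step that bears most directly on it is a 35-fold higher number from compound 2 to compound 3 (1.54 log units; beyond the scatter), in which a dimethylamino end on a plain chain went with a much higher number; compound 4 has no such end and carries a pentyl chain, close in kind to the chain of compound 2, and the step of a 65-fold higher number from compound 1 to compound 3 (1.81 log units; beyond the scatter) points the same way. A large step downward is therefore expected, a 17-fold lower number from compound 3 to compound 4 (1.24 log units; beyond the scatter). Compound 4 is estimated at 3 nM, with a range from 0.8 nM to 12 nM.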

Compound 4, inhibition constant: 1.9 nM
For compound 4 the middle estimate is 1.6-fold (0.20 log units) above the measured one; measured number inside the range.
By their numbers in this assay, from the lowest: compounds 1, 2 and 4 (each within the scatter of the next, the first and the last beyond it); then compound 3.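

Compound 4 shows that this position needs no sulfur or oxygen between the aromatic carbon and the chain: in this assay, removing (3-(dimethylamino)propyl)sulfanyl in favour of a pentyl chain joined directly to the ring gives a large drop (a 27-fold lower number from compound 3 to compound 4 (1.44 log units; beyond the scatter)), and the number returns to the low group formed by the plain-chain compounds, with compound 3 alone standing apart. Pentyl and hexylsulfanyl cannot be told apart (a 1.3-fold higher number from compound 2 to compound 4 (0.10 log units; within the scatter)), whereas the comparison with isopentyloxy shows a modest step beyond the scatter (a 2.4-fold higher number from compound 1 to compound 4 (0.38 log units; beyond the scatter)), so the plain chains are not fully equivalent even though compound 1 and compound 2 lie within the scatter of each other. The data at hand offer no independent measurement that would explain any of these differences.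

As far as these compounds go, the step from compound 3 to compound 4 changes the sulfur and the dimethylamino end together, so it remains open what a dimethylamino end would do on a chain joined directly through carbon. From the compounds shown here alone, how short the chain can become, as with methyl or ethyl, and whether a hydroxyl or a carboxylic acid at its end would act as dimethylamino does, also remain open.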